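The source may report more compounds than this note shows. Statements on the series, on what has been measured and on what is new or still open speak of the compounds shown alone.

Three compounds of the shared core carry numbers in a functional assay on MDA-MB-231 cells (Homo sapiens) for cytotoxicity, read by MTT assay, with a stated time of 48 h; on this read-out higher numbers stand for weaker inhibition and lower numbers for stronger inhibition. Compound 1 `COc1cc(-n2c(-c3ccc(F)cc3)csc2=S)cc(OC)c1OC` gives 19.5 ug/mL in this assay. Compound 2 `COc1cc(-n2c(-c3ccc(Cl)cc3)csc2=S)cc(OC)c1OC` reaches only the limit of > 100 ug/mL in this assay. Compound 3 `COc1cc(-n2c(-c3ccc(O)c(O)c3)csc2=S)cc(OC)c1OC` gives 29.8 ug/mL in this assay. Of the two plain numbers compound 3 holds the higher, yet the step of a 1.5-fold higher number from compound 1 to compound 3 (0.18 log units; within the scatter) lies within the scatter, so the two are not separated. The step of an at least 5.1-fold higher number from compound 1 to compound 2 (0.70 log units; beyond the scatter) and, in the other direction, an at least 3.3-fold lower number from compound 2 to compound 3 (0.52 log units; beyond the scatter) both lie beyond the scatter; one of the three values sits at the limit of > 100 ug/mL in this assay, at which 1 of the 3 values shown sits.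

Compound 4 `COc1ccc(-c2csc(=S)n2-c2cc(OC)c(OC)c(OC)c2)cc1` is not yet measured; it differs from compound 3 by 4-methoxyphenyl in place of 3,4-dihydroxyphenyl on an aromatic carbon. Among the measured compounds shown here, the steps that bear on this change are a 1.5-fold higher number from compound 1 to compound 3 (0.18 log units; within the scatter) and an at least 3.3-fold lower number from compound 2 to compound 3 (0.52 log units; beyond the scatter), which show that exchanging the group on this aromatic carbon can leave the number where it is or move it beyond the scatter, with the limit remaining a possible outcome. For compound 4 the expected step is a 1.2-fold higher number from compound 3 to compound 4 (0.07 log units; within the scatter), close to no change. For compound 4 the estimate in this assay is 35 ug/mL, between 12 ug/mL and 100 ug/mL.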

Compound 4, half-maximal inhibitory concentration: 53.8 ug/mL
For compound 4 the middle estimate is 1.5-fold (0.19 log units) below the measured one; low and high end bracket the measured number.
By their numbers in this assay, from the lowest: compounds 1, 3 and 4 (each within the scatter of the next, the first and the last beyond it). At a limit, above all of these: compound 2.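

Among the compounds shown here, exchanging 3,4-dihydroxyphenyl for 4-methoxyphenyl at this position gives a 1.8-fold higher number from compound 3 to compound 4 (0.26 log units; within the scatter), so in this assay a group with 0 hydrogen-bond donors is not separated from one with 2, whereas a 2.8-fold higher number from compound 1 to compound 4 (0.44 log units; beyond the scatter) is the first step between two plain numbers at this position that clears the scatter, with compound 3 separated from neither of those two compounds. Against the 4-chlorophenyl member, the step reads an at least 1.8-fold lower number from compound 2 to compound 4 (0.26 log units; that floor lies within the scatter), and since this is only a floor, the present reading does not separate that pair. Compound 2 remains at a limit and has no plain number: the limit of > 100 ug/mL in this assay, at which 1 of the 4 values shown sits.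

Open, from the compounds shown here alone, is how this aromatic carbon would respond to a phenyl group carrying an amine, a carboxylic acid or a single hydroxyl, or to a bromo in place of the chloro, which would test whether the limit belongs to chloro alone. All four compounds keep the rest of the shared core unchanged, so the compounds shown cannot tell whether these readings would hold on a different core.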